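Swapping the amide end of a dienamide: compound 4

The compounds below may be only part of what the source reports. "The series", "measured", "known", "first", "only" and "open" are said of these compounds alone.

Of the compounds shown here, three that share a core have been tested in a functional assay on A549 cells (Homo sapiens) for antiproliferative activity, read by sulforhodamine B assay, with a stated time of 48 h; on this read-out lower numbers stand for stronger inhibition and higher numbers for weaker inhibition. Compound 1 `CCNC(=O)/C=C/C=C/[C@H](O)Cc1ccc(OC)c(OC)c1` gives 13800 nM; compound 3 `COc1ccc(C[C@@H](O)/C=C/C=C/C(=O)NCc2ccccc2)cc1OC` gives 17100 nM; compound 2 `COc1ccc(C[C@@H](O)/C=C/C=C/C(=O)N2CCN(C)CC2)cc1OC` gives 22200 nM. Compound 2 holds the highest number of the three, yet its gaps to the others are small: a 1.6-fold higher number from compound 1 to compound 2 (0.21 log units; within the scatter) and a 1.3-fold lower number from compound 2 to compound 3 (0.11 log units; within the scatter) both lie within the scatter, as does a 1.2-fold higher number from compound 1 to compound 3 (0.09 log units; within the scatter). In other words, changing the group on the carbonyl carbon among ethylamino, benzylamino and 4-methylpiperazin-1-yl has not shifted the read-out beyond measurement noise.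

Compound 4 `COc1ccc(C[C@@H](O)/C=C/C=C/C(=O)N2CCN(c3ncccn3)CC2)cc1OC` is not yet measured. It differs from compound 2 in one place: pyrimidin-2-yl in place of methyl on an amine nitrogen in a ring. Among the measured compounds shown here, the closest precedent in the set is the step from compound 1 to compound 3, where an aromatic ring entered at the amide end and the number moved only within the scatter. For the measured compounds named here, no measured pair tests a pyrimidin-2-yl on this amine nitrogen, so this is the only guide.

On that basis compound 4 is expected to stay close to compound 2 in this assay, with a 1.4-fold lower number from compound 2 to compound 4 (0.14 log units; within the scatter) judged as no change beyond the scatter. The estimate for compound 4 is 16000 nM, within a range from 5000 nM to 50000 nM.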

Compound 4, half-maximal inhibitory concentration: 9920 nM
Compound 4: the middle estimate sits 1.6-fold (0.21 log units) above what was measured; low and high end bracket the measured number.
By their numbers in this assay, from the lowest: compounds 4, 1, 3 and 2 (each within the scatter of the next, the first and the last beyond it).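

In this assay, putting pyrimidin-2-yl in place of methyl on the amine nitrogen in the ring gives a 2.2-fold lower number from compound 2 to compound 4 (0.35 log units; beyond the scatter), a modest step but the first in this set to pass beyond the scatter. The earlier swaps on the carbonyl carbon all stayed within the scatter, so this result shows that the far end of the amide group can still move the number: a change made on the ring nitrogen, with one six-membered aromatic ring entering where a single methyl carbon left, has a measurable effect. The data shown give no measurement that would explain why this change lowers the number.

From the compounds shown here alone, a phenyl or a pyridin-2-yl group on the same amine nitrogen would separate the effect of the aromatic ring itself from that of its two ring nitrogens, and that question stays open. Also open, going by these compounds, is whether a simple ethyl or benzyl group on that nitrogen would shift the number as well, which would show whether any group larger than methyl is enough or whether an aromatic ring attached directly to the nitrogen is needed.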